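Fluorine on the benzyl ring of a glycinamide series

The compounds below may be only part of what the source reports. "The series", "measured", "known", "first", "only" and "open" are said of these compounds alone.

Compound 3 `CN(Cc1ccccc1)C(=O)CNC(=O)c1ccc(S(C)(=O)=O)c([N+](=O)[O-])c1` is the weaker of the two compounds that give a number in an assay on isolated protein for inhibition of thyroid hormone receptor beta (Homo sapiens), read by fluorescence polarization (on this read-out lower numbers stand for stronger inhibition and higher numbers for weaker inhibition), where compound 3 gives 39000 nM. Its nearest neighbour is compound 2 `CN(Cc1ccccc1F)C(=O)CNC(=O)c1ccc(S(C)(=O)=O)c([N+](=O)[O-])c1`, which in this assay gives 24000 nM, and the gap between them, a 1.6-fold higher number from compound 2 to compound 3 (0.21 log units; within the scatter), is within the scatter. A third compound, compound 1 `CN(Cc1cccc(F)c1)C(=O)CN(C)C(=O)c1ccc(S(C)(=O)=O)c([N+](=O)[O-])c1`, carries a methyl on the glycine nitrogen and in this assay gives only a limit, > 60000 nM; this value is a limit of the assay and not a number (the limit of > 60000 nM in this assay, at which 1 of the 3 values shown sits).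

The change to compound 4 `CN(Cc1cccc(F)c1)C(=O)CNC(=O)c1ccc(S(C)(=O)=O)c([N+](=O)[O-])c1` is fluoro in place of hydrogen on an aromatic carbon. Within the data shown here, the only measured step that bears on a fluoro on this benzyl ring is the one from compound 2 to compound 3, which was within the scatter, and no step between a fluoro placed as in compound 4 and a bare benzyl has been measured. The expectation is therefore that compound 4 differs little from compound 3 in this assay, with a step of a 1.2-fold lower number from compound 3 to compound 4 (0.09 log units; within the scatter) that is not beyond the scatter. Compound 4 is estimated at 32000 nM in this assay, with a range from 13000 nM to 70000 nM.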

Compound 4, half-maximal inhibitory concentration: > 60000 nM
Compound 4: only a limit was reported (the forecaster's own chance of this, stated with the estimate: 25%); at least 1.8-fold (0.27 log units) between middle value and limit.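

Placing the fluoro differently on the benzyl ring separates two compounds for the first time: 3-fluorophenyl in place of 2-fluorophenyl gives an at least 2.5-fold higher number from compound 2 to compound 4 (0.39 log units; beyond the scatter), whereas the only earlier readable step stayed within the scatter. Against the bare benzyl, the same fluoro gives an at least 1.5-fold higher number from compound 3 to compound 4 (0.18 log units; that floor lies within the scatter), so the floor of this step does not show that the fluoro changes the result, although the true step may be larger. In this assay, compound 4 gives a limit and not a number, as compound 1 does, and the step between these two compounds cannot be read: the limit of > 60000 nM in this assay, at which 2 of the 4 values shown sit.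

The compounds shown leave open how far compound 4 really lies from compound 3, and whether a chloro or a methoxy on the same aromatic carbon would read like the fluoro. They also leave open what the methyl on the amide-type nitrogen does on its own, since the pair that differs there gives no readable step.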